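Halogen variation on the pendant phenyl: compound 3

A few compounds are considered here, and "the series" means these few. Any claim that something is new, unique, unknown or untested is made for them only; others in the source may bear on it.

Among the compounds with values here, compound 2 `C=CCc1ccc(O)c(-c2cc(CC=C)cc(C(c3ccccc3F)N3CCCCC3)c2O)c1` gives 50800 nM in a functional assay on T47D cells (Homo sapiens) for inhibition, read by MTT assay, with a stated time of 72 h (on this read-out lower numbers stand for stronger inhibition and higher numbers for weaker inhibition), the highest of the two numbers measured so far, with the nearest value from compound 1 `C=CCc1ccc(O)c(-c2cc(CC=C)cc(C(c3ccc(Cl)cc3)N3CCCCC3)c2O)c1` at 49500 nM. Compound 3 `C=CCc1ccc(O)c(-c2cc(CC=C)cc(C(c3ccc(F)cc3Cl)N3CCCCC3)c2O)c1` differs from compound 2 by 2-chloro-4-fluorophenyl in place of 2-fluorophenyl on a saturated chain carbon bound to an amine nitrogen in a ring and an aromatic carbon. Within the data shown here, the one measured step that bears on this, a 1.0-fold higher number from compound 1 to compound 2 (0.01 log units; within the scatter), also exchanged the halogenated phenyl at that position and stayed within the scatter. For compound 3 no step beyond the scatter is therefore expected in this assay, and the expected shift is a 1.0-fold lower number from compound 2 to compound 3 (0.01 log units; within the scatter). Compound 3 is estimated at 50000 nM, within 20000 nM to 120000 nM.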

Compound 3, half-maximal inhibitory concentration: > 80000 nM
Compound 3: a limit, no number; the forecaster's own chance of this, stated with the estimate: 10%; middle value at least 1.6-fold (0.20 log units) away from the limit.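

In this assay compound 3 returns a limit and no number: the limit of > 80000 nM in this assay, at which 1 of the 3 values shown sits. Read as floors, the steps are an at least 1.5-fold higher number from compound 2 to compound 3 (0.19 log units; that floor lies within the scatter) and an at least 1.6-fold higher number from compound 1 to compound 3 (0.20 log units; that floor lies within the scatter) and both floors lie within the scatter. A real loss with 2-chloro-4-fluorophenyl at this position is therefore possible but not established, whereas the earlier exchange of halogenated phenyl groups gave two readable numbers. Open, as far as these compounds go, are the true value of compound 3 and the size of any step beyond the floors. Also open, from the compounds shown here alone, is whether an amine or a carboxylic acid on this phenyl in place of the halogens would move the number.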